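The source may report more compounds than this note shows. Statements on the series, on what has been measured and on what is new or still open speak of the compounds shown alone.

Compound 1 `Nc1nccc(COc2ccc3nc(N[C@@H]4CCCC[C@H]4O)sc3c2)c1Cl`: > 99%, a limit
Compound 2 `COc1cc(OCc2ccnc(N)c2Cl)cc2sc(N[C@@H]3CCCC[C@H]3O)nc12`: 98.7%

Within the data shown here, in an ADME assay on a cell-free system (plasma, Homo sapiens) for protein binding, read by LC-MS, with a stated time of 5 h, tested at 5 uM, compound 2 gives 98.7%, the only exact number so far. Compound 3 `Nc1nccc(COc2cc(Cl)c3nc(N[C@@H]4CCCC[C@H]4O)sc3c2)c1Cl` carries chloro in place of methoxy on an aromatic carbon. Among the measured compounds shown here, one measured step bears on this, also at that carbon's methoxy: an at least 1.3-fold higher unbound fraction from compound 1 to compound 2 (0.11 log units; that floor lies within the scatter). That step is only a floor, set by the limit of > 99% in this assay, at which 1 of the 2 values shown sits. The expected step in this assay is a 1.4-fold lower unbound fraction from compound 2 to compound 3 (0.16 log units; within the scatter), no larger than the scatter, with less free compound if anything. Compound 3 is estimated at 99.1%, within an expected range of 98.2% to 99.7%.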

Compound 3, plasma protein binding: > 99%
Compound 3 was reported as a limit (the forecaster's own chance of this, stated with the estimate: 50%); the middle value lies beyond the limit too.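

At this carbon, chloro in place of methoxy gives an at least 1.3-fold lower unbound fraction from compound 2 to compound 3 (0.11 log units; that floor lies within the scatter), so a second change at the position can also be read only as a floor. The result for compound 3 is a limit, and of the three groups seen here, only methoxy in compound 2 gives an exact number. The step from compound 1 to compound 3 cannot be read, because both values are limits: the limit of > 99% in this assay, at which 2 of the 3 values shown sit.

As far as these compounds go, the true size of the chloro step stays open. So does whether an amine or a carboxylic acid at this carbon would move the unbound fraction beyond the scatter.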